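The compounds below may be only part of what the source reports. "The series", "measured", "known", "first", "only" and "open" are said of these compounds alone.

In a functional assay on NCI-H460 cells (Homo sapiens) for inhibition, with a stated time of 72 h (on this read-out higher numbers stand for weaker inhibition and lower numbers for stronger inhibition), the compounds measured so far are:

Compound 1 `COc1ccc(S(=O)(=O)N2CCc3cccc(-c4ccc(N)cc4)c32)cc1`: 288 nM
Compound 2 `COc1ccc(S(=O)(=O)N2CCc3cccc(-c4ccc(F)c(F)c4)c32)cc1`: 46 nM
Compound 3 `COc1ccc(S(=O)(=O)N2CCc3cccc(-c4ccncc4)c32)cc1`: 101 nM

Compound 3 holds the middle place among these numbers, with a 2.2-fold higher number from compound 2 to compound 3 (0.34 log units; beyond the scatter) and a 2.9-fold lower number from compound 1 to compound 3 (0.46 log units; beyond the scatter). Compound 4 `COc1ccc(S(=O)(=O)N2CCc3cccc(-c4ccc(O)cc4)c32)cc1` is still unmeasured and differs from it by 4-hydroxyphenyl in place of pyridin-4-yl on an aromatic carbon, with 4-hydroxyphenyl in place of pyridin-4-yl on an aromatic carbon. The closest guide is a 2.9-fold lower number from compound 1 to compound 3 (0.46 log units; beyond the scatter), which removes 4-aminophenyl, the measured group nearest in kind to 4-hydroxyphenyl. Read in reverse, it points to a higher number. The other step, a 6.3-fold lower number from compound 1 to compound 2 (0.80 log units; beyond the scatter), shows that the choice of phenyl group matters, so the size remains uncertain. A modest rise is expected, namely a 1.7-fold higher number from compound 3 to compound 4 (0.23 log units; within the scatter). For compound 4 the estimated value is 170 nM, with an expected range of 60 nM to 450 nM.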

Compound 4, half-maximal inhibitory concentration: 114 nM
Beside the measured number, compound 4's estimate is 1.5-fold (0.17 log units) above it; low and high end bracket the measured number.
By their numbers in this assay, from the lowest: compound 2; then compounds 3 and 4 (each within the scatter of the next); then compound 1.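

In this assay, the step from pyridin-4-yl to 4-hydroxyphenyl gives a 1.1-fold higher number from compound 3 to compound 4 (0.05 log units; within the scatter), so these two groups cannot be told apart at this position on the aromatic carbon. Hydroxy in place of amino on the phenyl ring gives a 2.5-fold lower number from compound 1 to compound 4 (0.40 log units; beyond the scatter), which shows that this one substituent alone moves the number, while the step from 3,4-difluorophenyl to 4-hydroxyphenyl gives a 2.5-fold higher number from compound 2 to compound 4 (0.39 log units; beyond the scatter). Nothing available explains these steps. From the compounds shown here alone, it remains open whether a carboxylic acid or a hydroxymethyl group on the phenyl ring would give a number like that of hydroxy or that of amino.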